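The compounds below may be only part of what the source reports. "The series", "measured", "known", "first", "only" and "open" are said of these compounds alone.

Measured in a functional assay on CHO cells with adenosine receptor A1 (Homo sapiens) as the target, read by cAMP accumulation and immunoassay, with a stated time of 6 min, tested at 0.01 uM; a higher number here means a weaker effect of the compound at the concentration tested, a lower number a stronger effect:

- compound 1 `Nc1scc(CN2CCN(c3ccc(Cl)c(C(F)(F)F)c3)CC2)c1C(=O)c1ccc(Cl)cc1`: -2.5%
- compound 2 `Nc1scc(CN2CCN(c3cccc4ccccc34)CC2)c1C(=O)c1ccc(Cl)cc1`: 8.7%
- compound 3 `Nc1scc(CN2CCN(c3cc(F)cc(F)c3)CC2)c1C(=O)c1ccc(Cl)cc1`: -13%

All three share one core and differ only in the aryl group on the amine nitrogen in the ring. Compound 3 stands lowest of the three in this assay: its nearest neighbour is compound 1, with the step of a number 10.5 percentage points lower from compound 1 to compound 3 (beyond the scatter); its furthest is compound 2, with the step of a number 21.7 percentage points lower from compound 2 to compound 3 (beyond the scatter). Both steps lie beyond the scatter, though both are modest.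

Compound 4 `Nc1scc(CN2CCN(c3ccc(F)c(Cl)c3)CC2)c1C(=O)c1ccc(Cl)cc1` has not yet been measured in this assay. It differs from compound 3 in one place: 3-chloro-4-fluorophenyl in place of 3,5-difluorophenyl on an amine nitrogen in a ring. The change thus keeps a halogen-bearing phenyl on the same ring nitrogen, as in compound 1 and compound 3, rather than moving to a fused ring as in compound 2. Among the measured compounds shown here, the steps that bear on it, from compound 1 and from compound 2 to compound 3, show that swapping one aryl group for another here shifts the number only modestly. Compound 4 is therefore expected to land between compound 3 and compound 1, with a step of a number 6 percentage points higher from compound 3 to compound 4 (within the scatter) that stays within the scatter. The estimate for compound 4 in this assay is -7%, with a range from -20% to 6%.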

Compound 4, a percentage reported as activity, at one concentration (the size of the read-out at that concentration, not a potency): 4.2%
For compound 4 the middle estimate is 11.2 percentage points below the measured one; measured number inside the range.
By their numbers in this assay, from the lowest: compound 3; then compounds 1, 4 and 2 (each within the scatter of the next, the first and the last beyond it).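

In this assay, the step of a number 17.2 percentage points higher from compound 3 to compound 4 (beyond the scatter) shows that this position on the ring nitrogen can separate two halogen-bearing phenyl groups beyond the scatter, even though 3,5-difluorophenyl and 3-chloro-4-fluorophenyl both have 8 heavy atoms and neither has a hydrogen-bond donor or acceptor. Compound 4 cannot be told apart from either of the two larger aryl compounds, as the step of a number 4.5 percentage points lower from compound 2 to compound 4 (within the scatter) and the step of a number 6.7 percentage points higher from compound 1 to compound 4 (within the scatter) both lie within the scatter, so among the compounds shown only 3,5-difluorophenyl stands apart from all the others, with the lowest number. Nothing measured here explains why this exchange of halogens on the phenyl ring moves the number.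

The exchange alters both the set of halogens and where they sit on the phenyl ring, and the compounds shown do not separate these two changes. Also open, from the compounds shown here alone, is what a plain unsubstituted phenyl, or a phenyl carrying a methoxy group, would give on the same ring nitrogen.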